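This account rests on a few compounds, and the source may have more. Where it says the series, first, only, none or still open, it means among the compounds named here.

Compound 1 `CCOc1ccc(-n2nncc2CN2C(=O)C3(C(C#N)=C(N)Oc4c3c3nc5ccccc5nc3c3ccccc43)c3ccccc32)cc1` — > 50000 nM
Compound 2 `CC(=O)Nc1ccc(-n2nncc2CN2C(=O)C3(C(C#N)=C(N)Oc4c(N)cc5nc6ccccc6nc5c43)c3ccccc32)cc1` — > 50000 nM

Both compounds were tested in an ADME assay on HUVEC cells (Homo sapiens) for antiproliferative activity, read by MTT assay, with a stated time of 48 h; a higher number here means a weaker inhibitor, a lower number a stronger inhibitor. The value for compound 1 is a limit of the assay, not a number. The value for compound 2 is likewise a limit. Compound 2 therefore stands at the limit of > 50000 nM in this assay, at which 2 of the 2 values shown sit, and nothing in the numbers sets the two measured compounds apart.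

Compound 3 `COc1cc(-n2nncc2CN2C(=O)C3(C(C#N)=C(N)Oc4c(N)cc5nc6ccccc6nc5c43)c3ccccc32)c(OC)cc1Cl` has not yet been measured. It differs from compound 2 in one place: 4-chloro-2,5-dimethoxyphenyl in place of 4-acetamidophenyl on an aromatic nitrogen. Going by the values given here, no step between measured compounds has been recorded, so there is no measured change against which to weigh the new group. With both measured values sitting at the same limit, compound 3 is expected to show no step beyond the usual scatter, that is a number no higher from compound 2 to compound 3 (the limit leaves the size open) in this assay. Compound 3 is accordingly estimated at 50000 nM in this assay, within a range from 20000 nM to 200000 nM, and most likely reported again only as a limit.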

Compound 3, half-maximal inhibitory concentration: > 50000 nM
Compound 3: a limit, no number; the forecaster's own chance of this, stated with the estimate: 85%; the middle value lies on the limit itself.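

In this assay, going by these compounds alone, compound 2 and compound 3 both stand at a limit, not at a number, and no step between them can be read. The compounds shown leave open whether 4-chloro-2,5-dimethoxyphenyl and 4-acetamidophenyl differ in effect at all, and at what concentration, if any, these compounds would inhibit proliferation.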